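The compounds below may be only part of what the source reports. "The series", "measured", "known", "first", "only" and "open" are said of these compounds alone.

Measured compounds:
- compound 1, `C[C@@H](Cn1ccc(-c2ccc(C#N)c(Cl)c2)n1)NS(=O)(=O)c1cccnc1`: > 30000 nM
- compound 2, `C[C@@H](Cn1ccc(-c2ccc(C#N)c(Cl)c2)n1)Nc1ccccc1`: 3210 nM
- compound 3, `C[C@@H](Cn1ccc(-c2ccc(C#N)c(Cl)c2)n1)Nc1ccccn1`: "not determined" (no result reported)

All three share one core and differ only in the group carried on the amine nitrogen. In an ADME assay on PC-3 cells (Homo sapiens) for cytotoxicity, read by CCK-8 assay, with a stated time of 6 days (on this read-out higher numbers stand for weaker inhibition and lower numbers for stronger inhibition), compound 1 gives only a limit, > 30000 nM, which is a limit of the assay and not a number (the limit of > 30000 nM in this assay, at which 1 of the 3 values shown sits). In this assay compound 2 gives 3210 nM. Among the compounds with values here, the step of an at least 9.3-fold lower number from compound 1 to compound 2 (0.97 log units; beyond the scatter) is the only measured step here. Within the data shown here, for compound 3 no result was reported in this assay, so the only number close to it is that of compound 2.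

Compound 4, `C[C@@H](Cn1ccc(-c2ccc(C#N)c(Cl)c2)n1)Nc1ncccn1`, is not yet measured. It differs from compound 3 by pyrimidin-2-yl in place of pyridin-2-yl on an amine nitrogen; cut one bond further out, the change reads (pyridin-2-yl)amino to (pyrimidin-2-yl)amino. Among the measured compounds shown here, no measured step covers this exchange, and no number for compound 3 anchors it, so expectation can rest only on compound 2, whose value was 3210 nM. Compound 4 is therefore estimated at 6000 nM in this assay, expected to fall between 1500 nM and 30000 nM, with a real chance that only a limit is reported.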

Compound 4, half-maximal inhibitory concentration: > 30000 nM
Compound 4 was reported as a limit (the forecaster's own chance of this, stated with the estimate: 30%); middle value at least 5.0-fold (0.69 log units) away from the limit.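

In this assay, pyrimidin-2-yl in place of phenyl on the amine nitrogen gives an at least 9.3-fold higher number from compound 2 to compound 4 (0.97 log units; beyond the scatter), so carrying a six-membered aromatic ring on this nitrogen is not enough to keep the read-out of compound 2. The result for compound 4 is a limit of the assay and not a number, and a second, quite different group now ends at that same limit: the limit of > 30000 nM in this assay, at which 2 of the 4 values shown sit. Compound 1 and compound 4 are both limits, so the step between them cannot be read.

Going by these compounds, whether pyridin-2-yl in compound 3 reads closer to phenyl or to pyrimidin-2-yl stays open. Also open, on these data alone, is how a saturated ring such as cyclohexyl, or an acetyl group, would read on the same nitrogen.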